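The source may hold more compounds than are shown below. What is called first, only, known or untested is meant among the compounds shown, and "the series" means these compounds.

In a functional assay on the whole organism (strain Hartley) for inhibition, with Cavia porcellus as the target, with stated times of 2 min and 15 min (a lower number here means that less compound is needed, a higher number that more compound is needed for the effect), compound 1 `CCCCC[C@H](O)/C=C/C1CCC(=O)[C@@H]1CCCCSCC(=O)O` gives 0.00507 mg/kg, while compound 2 `CCCCC[C@@H](O)/C=C/C1CCC(=O)[C@@H]1CCCCSCC(=O)O` gives 0.0113 mg/kg, the higher of the two numbers. Among the measured compounds shown here, the only measured step, a 2.2-fold higher number from compound 1 to compound 2 (0.35 log units; beyond the scatter), inverts a stereocentre at a saturated chain carbon, and this same carbon changes again in compound 3 `CCCCC[C@](C)(O)/C=C/C1CCC(=O)[C@@H]1CCCCSCC(=O)O`. There, methyl in place of hydrogen on a saturated chain carbon bound to a double-bonded chain carbon, an oxygen on a saturated carbon and a saturated chain carbon describes methyl in place of hydrogen. For the measured compounds named here, the modest size of a 2.2-fold higher number from compound 1 to compound 2 (0.35 log units; beyond the scatter) is the only guide, and it involves no added group, so the expected change in this assay stays within the scatter, an estimated 1.1-fold lower number from compound 2 to compound 3 (0.05 log units; within the scatter). For compound 3 the estimate is 0.01 mg/kg, with an expected range from 0.003 mg/kg to 0.04 mg/kg.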

Compound 3, dose for half-maximal effect: 0.00185 mg/kg
Compound 3: the middle estimate sits 5.4-fold (0.73 log units) above what was measured; measured number outside the range, below it.
By their numbers in this assay, from the lowest: compound 3; then compound 1; then compound 2.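

The carbon bearing the hydroxyl need not keep its hydrogen: with methyl in its place, this assay shows a 6.1-fold lower number from compound 2 to compound 3 (0.79 log units; beyond the scatter) and also a 2.7-fold lower number from compound 1 to compound 3 (0.44 log units; beyond the scatter) and so compound 3 has the lowest number of the three. Adding the methyl thus takes the number below what either configuration of the hydrogen-bearing carbon reached in compound 1 and compound 2.

From the compounds shown here alone, whether an ethyl group or a fluorine atom on this carbon would do the same stays open, as does the opposite configuration of the methyl-bearing carbon. Nothing shown bears on the reason for the number of compound 3.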